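The source may hold more compounds than are shown below. What is called first, only, known or untested is meant among the compounds shown, and "the series" means these compounds.

Measured so far in an assay on HEK293 cells for agonist activity at probable G-protein coupled receptor 34 (Mus musculus), with a stated time of 1 h; a higher number here means a larger maximal response, a lower number a smaller maximal response:

compound 1 `N[C@@H](COP(=O)(O)OCCOC(=O)CCc1ccccc1OCc1cccc(Oc2ccccc2)c1)C(=O)O` gives 12.4%
compound 2 `C[C@H](COC(=O)CCc1ccccc1OCc1cccc(Oc2ccccc2)c1)OP(=O)(O)OC[C@H](N)C(=O)O` gives 12.4%

Compound 2 stands level with compound 1 at the digits printed, with a gap inside the scatter; neither can be called the more or less active of the two. Among the measured compounds shown here, the one measured step, no change at the digits printed from compound 1 to compound 2 (within the scatter), puts methyl in place of hydrogen on a saturated chain carbon bound to an oxygen on an unsaturated carbon and a saturated chain carbon, and leaves the maximal response unchanged within the scatter.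

Compound 3 `COC[C@H](COC(=O)CCc1ccccc1OCc1cccc(Oc2ccccc2)c1)OP(=O)(O)OC[C@H](N)C(=O)O` is not yet measured. It differs from compound 2 as follows: methoxy in place of hydrogen on a saturated chain carbon, two bonds along the chain from an oxygen on an unsaturated carbon. For the measured compounds named here, the only measured step that bears on this change is the one from compound 1 to compound 2, which sits on the same part of the chain and was flat. Going by the values given here, no measured step shows what a methoxy entering at this place does, so the expectation rests on that flat step alone.

For compound 3 the expected step is a number 0.4 percentage points lower from compound 2 to compound 3 (within the scatter), that is, none beyond the scatter. Compound 3 is therefore estimated at 12%, with a range of 3% to 25%.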

Compound 3, largest response reached (Emax), in percent of the reference or control that the assay uses: 13.5%
Estimate against measurement, compound 3: 1.5 percentage points below; the range from low to high includes it.
By their numbers in this assay, from the lowest: compounds 1, 2 and 3 (each within the scatter of the next).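

In this assay the methoxy on the saturated chain carbon, two bonds along the chain from an oxygen on an unsaturated carbon, gives a number 1.1 percentage points higher from compound 2 to compound 3 (within the scatter) and so lies inside the usual spread of repeat measurements. Set against compound 1, which has only hydrogen at this place, methoxymethyl gives a number 1.1 percentage points higher from compound 1 to compound 3 (within the scatter) and is likewise within the scatter, so this part of the chain now carries both methyl and the larger methoxymethyl with no step beyond the scatter in maximal response, where the earlier pair covered methyl alone. No supporting data on these compounds speak to what lies behind these readings.

From the compounds shown here alone, all three compounds sit at a similarly low maximal response, so it remains open whether any group at this place can lift the response clear of the scatter, for example an amine, a carboxylic acid or a longer chain such as a butoxymethyl group. Also open is whether the same tolerance holds when the change is made elsewhere on the shared core, since every step shown falls on this one part of the chain.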